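Thiourea-Type Group to Carbamoyl: Cytotoxicity Outlook

A few compounds are considered here, and "the series" means these few. Any claim that something is new, unique, unknown or untested is made for them only; others in the source may bear on it.

Of the compounds shown here, three have been tested in an ADME assay on HEK-293T cells (Homo sapiens) for cytotoxicity, read by CCK-8 assay, with a stated time of 48 h; a higher number here means a weaker inhibitor, a lower number a stronger inhibitor. Compound 1 `COc1ccc(Oc2ccccc2-c2ccsc2S(=O)(=O)N2CCN(C(=O)Nc3ccc([N+](=O)[O-])cc3)CC2)cc1OC` reaches only a limit of the assay: in this assay compound 1 gives > 20000 nM, which is the limit of > 20000 nM in this assay, at which 1 of the 3 values shown sits. Going by the values given here, compound 2 `O=[N+]([O-])c1ccc(NC(=S)NCCNS(=O)(=O)c2ccc(-c3ccccc3O[C@H]3CC[C@@H](O)CC3)s2)cc1` is the one compound with a full number, and in this assay compound 2 gives 20000 nM. Compound 3 `COc1ccc(Oc2ccc([N+](=O)[O-])cc2-c2ccsc2S(=O)(=O)N2CCN(C(=S)Nc3ccc([N+](=O)[O-])cc3)CC2)cc1OC` again stops at a limit, and in this assay compound 3 gives > 50000 nM, described as the limit of > 50000 nM in this assay, at which 1 of the 3 values shown sits. So compound 3 stands among the weakest readings shown, with no number of its own and only a floor on how weak it is.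

Compound 4 `COc1ccc(Oc2ccc([N+](=O)[O-])cc2-c2ccsc2S(=O)(=O)N2CCN(C(=O)Nc3ccc([N+](=O)[O-])cc3)CC2)cc1OC` is the next compound. It differs from compound 3 by a group of 12 heavy atoms (7 carbon, 2 nitrogen, 3 oxygen; one six-membered aromatic ring of carbon only) in place of a group of 12 heavy atoms (7 carbon, 2 nitrogen, 2 oxygen, 1 sulfur; one six-membered aromatic ring of carbon only), on an amine nitrogen in a ring. Among the compounds with values here, no measured pair shows the effect of this change, so there is nothing to copy from. Since all three values shown are weak and two of them are limits, no step beyond the scatter is expected in this assay, in either direction. Compound 4 is therefore expected to give about 50000 nM, with a plausible range from 20000 nM to 100000 nM, and very likely to be reported only as a limit. This estimate means a step of a number no higher from compound 3 to compound 4 (the limit leaves the size open).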

Compound 4, half-maximal inhibitory concentration: > 20000 nM
Compound 4 was reported as a limit; the forecaster's own chance of this, stated with the estimate: 85%; the middle value does not contradict the limit.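

Compound 1, compound 3 and compound 4 all stop at limits, so neither step, from compound 3 to compound 4 or from compound 1 to compound 4, can be read. Going by these compounds, whether the (4-nitrophenyl)carbamoyl group or the added nitro changes cytotoxicity at all remains open.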